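Aryl selenide amines: methyl replacing fluoro on the ring

The source may report more compounds than this note shows. Statements on the series, on what has been measured and on what is new or still open speak of the compounds shown alone.

Of the compounds shown here, three have been measured in an assay on isolated protein for inhibition of Amine oxidase [flavin-containing] B (Homo sapiens), read by fluorescence and spectrophotometry; on this read-out lower numbers stand for stronger inhibition and higher numbers for weaker inhibition. Compound 1 `Cc1cccc(C)c1[Se]CC(C)N` gives 2790 nM, compound 2 `CC(N)CSc1ccccc1` gives 57300 nM, and compound 3 `CC(N)C[Se]c1ccc(F)cc1` gives 13400 nM. Compound 3 thus stands second highest of the three numbers in this assay; compound 2 is its nearest neighbour and compound 1 the furthest, both gaps beyond the scatter. Compound 4 `Cc1ccc([Se]CC(C)N)cc1` differs from compound 3 in one place: methyl in place of fluoro on an aromatic carbon. Among the measured compounds shown here, no measured pair differs in just this way, so the step size is unknown. Since compound 1, carrying methyl groups on its ring, gives 2790 nM, a moderate step toward a lower number is expected, a 2.2-fold lower number from compound 3 to compound 4 (0.35 log units; beyond the scatter). Compound 4 is accordingly estimated at 6000 nM, within 2000 nM to 18000 nM.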

Compound 4, half-maximal inhibitory concentration: 36500 nM
Beside the measured number, compound 4's estimate is 6.1-fold (0.78 log units) below it; the measured number lies above the stated range.
By their numbers in this assay, from the lowest: compound 1; then compound 3; then compounds 4 and 2 (each within the scatter of the next).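

Methyl in place of fluoro on an aromatic carbon, para to a group of 5 heavy atoms, gives a 2.7-fold higher number from compound 3 to compound 4 (0.44 log units; beyond the scatter) and is the first single-place step in the series. This position is therefore sensitive to the exchange of one single-atom-sized group for another, and here fluoro carries the lower number. Nothing at hand explains the step.

As far as these compounds go, whether chloro or methoxy at this position would give a lower number than fluoro remains open. So does whether the same exchange gives a similar step in the sulfur series.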